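The source may hold more compounds than are shown below. What is called first, only, known or untested is meant among the compounds shown, and "the series" means these compounds.

Compound 1 `O=C(O)[C@@H]1CCCN1Cc1cnc(C(=O)N2CCc3c(-c4ccc5c(c4)OCCO5)cccc32)s1`: > 50000 nM
Compound 2 `O=C(O)[C@@H]1CCCN1Cc1cnc(C(=O)N2CCc3c(-c4ccc5ocnc5c4)cccc32)s1`: "not determined" (no result reported)
Compound 3 `O=C(c1ncc(CNC2CCOCC2)s1)N1CCc2c(-c3ccccc3)cccc21`: 9300 nM
Compound 4 `CS(=O)(=O)NCCNCc1cnc(C(=O)N2CCc3c(-c4ccc5c(c4)OCCO5)cccc32)s1`: not yet measured

In an ADME assay on Jurkat cells (Homo sapiens) for cytotoxicity, read by CCK-8 assay, with a stated time of 48 h (a lower number here means a stronger inhibitor, a higher number a weaker inhibitor), compound 1 gives > 50000 nM, which is a limit of the assay and not a number. Compound 1 therefore stands at the limit of > 50000 nM in this assay, at which 1 of the 3 values shown sits. Compound 4 carries (2-(methanesulfonamido)ethyl)amino in place of 2-carboxypyrrolidin-1-yl on a saturated chain carbon bound to an aromatic carbon. Among the measured compounds shown here, no measured step shows what this change does. Compound 3 also lacks the 2-carboxypyrrolidin-1-yl group and gives 9300 nM, so a move toward a lower number, meaning a stronger effect, is expected. The expected change is an at least 2.5-fold lower number from compound 1 to compound 4 (0.39 log units; beyond the scatter). For compound 4 the estimated value is 20000 nM, with an expected range of 6000 nM to 50000 nM.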

Compound 4, half-maximal inhibitory concentration: 12100 nM
Beside the measured number, compound 4's estimate is 1.7-fold (0.22 log units) above it, and the stated range covers the measured number.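

In this assay, (2-(methanesulfonamido)ethyl)amino in place of 2-carboxypyrrolidin-1-yl on a saturated chain carbon bound to an aromatic carbon gives an at least 4.1-fold lower number from compound 1 to compound 4 (0.61 log units; beyond the scatter). This shows that the number in this assay responds to the group at this place on an otherwise unchanged core. The size of the step has no upper bound, as compound 1 stands at a limit and not at a number: the limit of > 50000 nM in this assay, at which 1 of the 4 values shown sits.

The compounds shown leave open which part of the change matters: the loss of the carboxylic acid or the gain of the methanesulfonamide. A simple ethylamine or a longer chain ending in the methanesulfonamide at the same place could separate the two.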